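The source may report more compounds than this note shows. Statements on the series, on what has been measured and on what is new or still open speak of the compounds shown alone.

Measured in an ADME assay on HOS cells (Homo sapiens) for cytotoxicity; a higher number here means that more compound is tolerated, a lower number that less compound is tolerated:
- Compound 1 `CN(Cc1nc2ccccc2n1CCN)C1CCCc2cccnc21`: > 20000 nM (a limit of the assay)
- Compound 2 `CN(Cc1nc2ccccc2n1CCCCN)C1CCCc2cccnc21`: 2900 nM

Among the compounds with values here, compound 2, at 2900 nM, holds the only actual number so far in this assay. Compound 3 `CN(Cc1nc2ccccc2n1CCCCCN)C1CCCc2cccnc21` differs from it as follows: aminomethyl in place of amino on a saturated chain carbon, four bonds along the chain from an aromatic nitrogen. Aminomethyl stands in place of amino on a saturated chain carbon, four bonds along the chain from an aromatic nitrogen.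

Within the data shown here, one measured step bears on this, an at least 6.8-fold lower number from compound 1 to compound 2 (0.83 log units; beyond the scatter). There 2-aminoethyl entered, whereas here only aminomethyl does, so a smaller change in the same direction is expected. The expected step is a 1.9-fold lower number from compound 2 to compound 3 (0.29 log units; within the scatter). Compound 3 is estimated at 1500 nM, with an expected range from 500 nM to 4500 nM.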

Compound 3, half-maximal cytotoxic concentration: 4500 nM
Estimate against measurement, compound 3: 3.0-fold (0.48 log units) below, within the range that was stated.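

In this assay, going one carbon further along the chain gives a 1.6-fold higher number from compound 2 to compound 3 (0.19 log units; within the scatter), so this extension, unlike the earlier one, brings no readable change. Against the shortest chain the difference persists, with an at least 4.4-fold lower number from compound 1 to compound 3 (0.64 log units; beyond the scatter). That step is only bounded, as the value of compound 1 is a limit: the limit of > 20000 nM in this assay, at which 1 of the 3 values shown sits.

As far as these compounds go, whether a still longer chain would leave the number where it stands remains open. So does the effect of a hydroxyl or a carboxylic acid in place of the amine.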